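The source may report more compounds than this note shows. Statements on the series, on what has been measured and on what is new or still open speak of the compounds shown alone.

Measured compounds:
compound 1, `CN(C)C(=O)c1cc2cnc(Nc3ccc(S(=O)(=O)NCCCCCN=C=S)cc3)nc2n1C1CCCC1`: 102%
compound 2, `CN(C)C(=O)c1cc2cnc(Nc3ccc(C(=O)NCCCN=C=S)cc3)nc2n1C1CCCC1`: 103%

In a functional assay on A549 cells (Homo sapiens) for inhibition, read by CCK-8 assay, with a stated time of 72 h, tested at 10 uM (on this read-out lower numbers stand for a weaker effect and higher numbers for a stronger effect at the one concentration tested), compound 2 gives 103%, and compound 1 gives 102%. Going by the values given here, the only measured step, a number 1 percentage points higher from compound 1 to compound 2 (within the scatter), lies within the scatter, so the two compounds cannot be told apart on this read-out; both sit at essentially complete inhibition at the one concentration tested.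

Compound 3, `CN(C)C(=O)c1cc2cnc(Nc3ccc(C(=O)NCCCN=C=S)cc3F)nc2n1C1CCCC1`, differs from compound 2 by fluoro in place of hydrogen on an aromatic carbon. Among the compounds with values here, no measured step touches this kind of change: the one step recorded exchanges the whole sulfonamide-bearing chain for the amide-bearing chain and leaves the aromatic ring untouched. What the two measured compounds do show is that large changes at the chain end left the read-out at the ceiling. A single fluoro on the ring is a far smaller change, and there is no measured basis for expecting it to move the number beyond the scatter in either direction in this assay.

Compound 3 is therefore estimated at 100%, within 85% to 106%, an expected step of a number 3 percentage points lower from compound 2 to compound 3 (within the scatter).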

Compound 3, a percentage reported as inhibition, at one concentration (the size of the read-out at that concentration, not a potency): 60.2%
Beside the measured number, compound 3's estimate is 39.8 percentage points above it, and the stated range ends above it.
By their numbers in this assay, from the lowest: compound 3; then compounds 1 and 2 (each within the scatter of the next).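

In this assay, fluoro in place of hydrogen on an aromatic carbon gives a number 42.8 percentage points lower from compound 2 to compound 3 (beyond the scatter), the only step beyond the scatter among the compounds shown. This shows that the ring position ortho to a large group and meta to a group of 9 heavy atoms is not indifferent: a change of a single heavy atom here moves the read-out, whereas the exchange of the whole chain end gave only a number 1 percentage points higher from compound 1 to compound 2 (within the scatter). Nothing available bears on why the fluoro has this effect.

The compounds shown leave open whether this drop belongs to fluoro itself or to any group at this place, a question that a chloro, methyl or methoxy group at the same carbon would address, and whether fluoro at another carbon of this ring would give the same result. They also leave open whether the same fluoro would lower the number on the sulfonamide-bearing chain of compound 1, and, with one concentration tested, how the compounds compare at any other concentration.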